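This account rests on a few compounds, and the source may have more. Where it says the series, first, only, none or still open, it means among the compounds named here.

Measured so far:
- compound 1, `COc1ccc(-c2ccnc(Nc3ccc4c(c3)c(/C=C3/C(=O)Nc5ccccc53)cn4C)n2)cc1`, in a functional assay on MCF7 cells (Homo sapiens) for cytotoxicity, read by MTT assay, with a stated time of 48 h; on this read-out lower numbers stand for stronger inhibition and higher numbers for weaker inhibition: > 100000 nM (a limit of the assay, not a number)
- compound 2, `Cn1cc(/C=C2/C(=O)Nc3ccccc32)c2cc(Nc3nccc(-c4ccc(F)cc4)n3)ccc21`, in this assay: 48100 nM

Both compounds share the same core and differ only in one group on the outer aromatic ring. For compound 1 the result is a limit of the assay rather than a number, and it gives > 100000 nM (the limit of > 100000 nM in this assay, at which 1 of the 2 values shown sits). Within the data shown here, compound 2 gives 48100 nM in this assay, the only real number among the two, so it stands as the single reference point. Among the measured compounds shown here, the measured step of an at least 2.0-fold lower number from compound 1 to compound 2 (0.31 log units; beyond the scatter) is the sole guide available.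

Compound 3, `Cn1cc(/C=C2/C(=O)Nc3ccccc32)c2cc(Nc3nccc(-c4ccc(Cl)cc4Cl)n3)ccc21`, has not yet been measured; it carries 2,4-dichlorophenyl in place of 4-fluorophenyl on an aromatic carbon. For the measured compounds named here, the one measured step concerned a different swap at the same place and was at least modest; a halogen-for-halogen exchange has no precedent of its own here. A step of comparable, modest size toward a lower number is therefore expected, with wide uncertainty. For compound 3 a value of 30000 nM is estimated, within 10000 nM to 100000 nM. This corresponds to an expected step of a 1.6-fold lower number from compound 2 to compound 3 (0.21 log units; within the scatter).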

Compound 3, half-maximal inhibitory concentration: > 100000 nM
Compound 3: no number, only a limit; the forecaster's own chance of this, stated with the estimate: 15%; middle value at least 3.3-fold (0.52 log units) away from the limit.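

Replacing 4-fluorophenyl with 2,4-dichlorophenyl on this aromatic carbon gives an at least 2.0-fold higher number from compound 2 to compound 3 (0.31 log units; beyond the scatter), so carrying halogen on the outer ring is not enough on its own to give a measurable number in this assay. In this assay, on these data alone, compound 3 gives > 100000 nM, which is a limit of the assay and not a number, so the full size of this step stays unknown. The step between compound 1 and compound 3 cannot be read, and of the three outer rings shown, only the 4-fluorophenyl of compound 2 gives a real number, while the other two end at the same limit: the limit of > 100000 nM in this assay, at which 2 of the 3 values shown sit.

The compounds shown leave open whether the change at this position turns on the swap of fluorine for chlorine or on the presence of a second halogen, and 4-chlorophenyl, with a single chlorine, would separate these two changes. They also leave open how this position responds to an unsubstituted phenyl or to a phenyl ring bearing an amine or a carboxylic acid.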